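The source may hold more compounds than are shown below. What is called first, only, known or untested is meant among the compounds shown, and "the series" means these compounds.

Compound 1 `c1ccc(-c2ccc3[nH]ncc3c2)cc1`, in an assay on CHO-TREX cells for antagonist activity at transient receptor potential cation channel subfamily A member 1 (Homo sapiens), read by FLIPR and calcium flux, with a stated time of 10 min (on this read-out higher numbers stand for weaker inhibition and lower numbers for stronger inhibition), a limit only: > 30000 nM
Compound 2 `Cc1ccccc1-c1ccc2[nH]ncc2c1`: 7810 nM
Compound 3 `FC(F)(F)c1ccccc1-c1ccc2[nH]ncc2c1`: 164 nM

Compound 1 stands at the limit of > 30000 nM in this assay, at which 1 of the 3 values shown sits, so only a limit, not a number, is known for it. Compound 4 `FC(F)(F)Oc1ccccc1-c1ccc2[nH]ncc2c1` differs from compound 1 by trifluoromethoxy in place of hydrogen on an aromatic carbon. Among the compounds with values here, two measured steps bear on this change, both placing a group on the same aromatic carbon of compound 1: an at least 3.8-fold lower number from compound 1 to compound 2 (0.58 log units; beyond the scatter) and an at least 180-fold lower number from compound 1 to compound 3 (2.26 log units; beyond the scatter). Both lowered the number, the trifluoromethyl step by far the more. A lowering beyond the scatter in this assay is therefore expected for compound 4 as well, probably nearer the trifluoromethyl case than the methyl case, as the estimated step of an at least 75-fold lower number from compound 1 to compound 4 (1.87 log units; beyond the scatter). Compound 4 is thus expected at about 400 nM, with a range from 100 nM to 3000 nM.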

Compound 4, half-maximal inhibitory concentration: 3430 nM
Compound 4: middle estimate off by 8.6-fold (0.93 log units), on the low side; the measured number lies above the stated range.
By their numbers in this assay, from the lowest: compound 3; then compound 4; then compound 2. At a limit, above all of these: compound 1.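

Trifluoromethoxy on this aromatic carbon still improves on hydrogen, with an at least 8.7-fold lower number from compound 1 to compound 4 (0.94 log units; beyond the scatter), but it gives up most of what trifluoromethyl gained, with a 21-fold higher number from compound 3 to compound 4 (1.32 log units; beyond the scatter). Its edge over methyl is only modest, with a 2.3-fold lower number from compound 2 to compound 4 (0.36 log units; beyond the scatter), so the presence of fluorine in the group does not by itself carry the trifluoromethyl result. On these data alone, how far any group improves on hydrogen here stays unsettled, since compound 1 is known only as a limit: the limit of > 30000 nM in this assay, at which 1 of the 4 values shown sits. How a nitrile, a methoxy group or an amine on this carbon would compare remains open.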